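The source may report more compounds than this note shows. Statements on the series, on what has been measured and on what is new or still open speak of the compounds shown alone.

Compound 2 `CC(C)c1onc(-c2c(Cl)cccc2Cl)c1COc1ccc(N(C)Cc2ccc(CCC(=O)O)cc2)c(C(F)(F)F)n1` stands lowest of the two numbers on hand: in a functional assay on HEK293 cells for agonist activity at Bile acid receptor (Homo sapiens) (on this read-out higher numbers stand for an effect only at larger amounts of compound and lower numbers for an effect already at smaller amounts), compound 2 gives 35 nM, while compound 1 `CC(C)c1onc(-c2c(Cl)cccc2Cl)c1COc1ccc(NCc2ccc(C(=O)O)cc2)c(C(F)(F)F)n1` gives 398 nM, a gap beyond the scatter. Compound 3 `CC(C)c1onc(-c2c(Cl)cccc2Cl)c1COc1ccc(N(C)Cc2cccc(C(=O)O)c2)c(C(F)(F)F)n1` is not yet measured; it differs from compound 2 by 3-carboxyphenyl in place of 4-(2-carboxyethyl)phenyl on a saturated chain carbon bound to a nitrogen on an aromatic ring. Going by the values given here, no measured pair isolates this change, so the step is uncertain; an upward move of moderate size is expected, as a 3.4-fold higher number from compound 2 to compound 3 (0.54 log units; beyond the scatter). For compound 3 the estimate in this assay is 120 nM, with a range from 35 nM to 450 nM.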

Compound 3, half-maximal effective concentration: 80 nM
Compound 3: the middle estimate sits 1.5-fold (0.18 log units) above what was measured, within the range that was stated.
By their numbers in this assay, from the lowest: compound 2; then compound 3; then compound 1.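

In this assay, 3-carboxyphenyl in place of 4-(2-carboxyethyl)phenyl on a saturated chain carbon bound to a nitrogen on an aromatic ring gives a modest loss, a 2.3-fold higher number from compound 2 to compound 3 (0.36 log units; beyond the scatter), so this position accepts both groups within a narrow span. (3-Carboxybenzyl)(methyl)amino in place of (4-carboxybenzyl)amino on an aromatic carbon gives a gain, a 5.0-fold lower number from compound 1 to compound 3 (0.70 log units; beyond the scatter). Nothing at hand bears on the cause of either step.

Each step changes more than one feature of the group, so the shares of chain length, carboxylic acid placement and nitrogen methyl stay unresolved. Going by these compounds, a tetrazole in place of the carboxylic acid also remains open.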